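From 1,3,4-thiadiazol-2-yl to 1-methyl-1H-tetrazol-5-yl on sulfur

The source may hold more compounds than are shown below. What is called first, only, known or untested is meant among the compounds shown, and "the series" means these compounds.

In a functional assay on MGC-803 cells (Homo sapiens) for antiproliferative activity, read by MTT assay, with a stated time of 48 h (a lower number here means a stronger inhibitor, a higher number a weaker inhibitor), compound 1 (`COc1ccc(CN(C(=O)Cn2cc(CSC3=NCCS3)nn2)c2cc(OC)c(OC)c(OC)c2)cc1`) gives 1610 nM and compound 2 (`COc1ccc(CN(C(=O)Cn2cc(CSc3nncs3)nn2)c2cc(OC)c(OC)c(OC)c2)cc1`) gives 5000 nM as the higher of the two numbers, which makes it the weaker of the pair. Compound 3 (`COc1ccc(CN(C(=O)Cn2cc(CSc3nnnn3C)nn2)c2cc(OC)c(OC)c(OC)c2)cc1`) carries 1-methyl-1H-tetrazol-5-yl in place of 1,3,4-thiadiazol-2-yl on a sulfur. For the measured compounds named here, one measured step bears on this sulfur, a 3.1-fold higher number from compound 1 to compound 2 (0.49 log units; beyond the scatter) on going from a non-aromatic to an aromatic five-membered ring. That step is modest and does not involve 1-methyl-1H-tetrazol-5-yl, so it gives no direction for one aromatic five-membered ring replacing another. The expected change is a 1.3-fold lower number from compound 2 to compound 3 (0.10 log units; within the scatter) and thus none beyond the scatter. In this assay the estimate for compound 3 is 4000 nM with 1300 nM to 12000 nM as the expected range.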

Compound 3, half-maximal inhibitory concentration: 6570 nM
Estimate against measurement, compound 3: 1.6-fold (0.22 log units) below, and the stated range covers the measured number.
By their numbers in this assay, from the lowest: compound 1; then compounds 2 and 3 (each within the scatter of the next).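

In this assay the change on the sulfur gives a 1.3-fold higher number from compound 2 to compound 3 (0.12 log units; within the scatter), so 1-methyl-1H-tetrazol-5-yl and 1,3,4-thiadiazol-2-yl cannot be told apart here, despite the different ring atoms and the added methyl. The comparison with the non-aromatic ring of compound 1 gives a 4.1-fold higher number from compound 1 to compound 3 (0.61 log units; beyond the scatter), so the lower number of compound 1 now stands against two different aromatic five-membered rings rather than one. No measured evidence bears on the cause of either step.

Going by these compounds, it remains open whether a six-membered ring such as pyridine, an open chain carrying an amine, or a carboxylic acid on this sulfur would stay with compound 1 or with the two aromatic rings. On these data alone, all three compounds keep the sulfur, so an oxygen or an amine nitrogen in its place also remains open.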